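This account rests on a few compounds, and the source may have more. Where it says the series, first, only, none or still open, it means among the compounds named here.

For the measured compounds named here, in a functional assay on HCT-116 cells (Homo sapiens) for inhibition (on this read-out lower numbers stand for stronger inhibition and higher numbers for weaker inhibition), three compounds on the shared core have numbers so far. Compound 1 `CCNC(=O)c1noc(-c2cc(C(C)C)c(O)cc2O)c1-c1cc(CN)no1` gives 84 nM, compound 2 `CCNC(=O)c1noc(-c2cc(C(C)C)c(O)cc2O)c1-c1cc(CN(C)C)no1` gives 92 nM and compound 3 `CCNC(=O)c1noc(-c2cc(C(C)C)c(O)cc2O)c1-c1cc(C(N)=O)no1` gives 79 nM. Compound 3 therefore holds no separate place among the three: the measured steps are a 1.1-fold lower number from compound 1 to compound 3 (0.03 log units; within the scatter) and a 1.2-fold lower number from compound 2 to compound 3 (0.07 log units; within the scatter).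

Compound 4 `CCNC(=O)c1noc(-c2cc(C(C)C)c(O)cc2O)c1-c1ccn(C)n1` exchanges the whole substituent on the aromatic carbon: 1-methyl-1H-pyrazol-3-yl in place of 3-carbamoyl-1,2-oxazol-5-yl on an aromatic carbon. The measured steps bear on this only indirectly. They change the group carried on the five-membered aromatic ring, and none replaces that ring. The closest guide is that the three different groups in those steps, together with a 1.1-fold higher number from compound 1 to compound 2 (0.04 log units; within the scatter), all stayed within the scatter. The data hold no direct test of a 1-methyl-1H-pyrazol-3-yl group, so the uncertainty is wider than the spread seen so far.

The expected result in this assay is no change beyond the scatter, with a 1.0-fold higher number from compound 3 to compound 4 (0.01 log units; within the scatter) as the estimated step. Compound 4 is estimated at 80 nM, with an expected range of 30 nM to 220 nM.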

Compound 4, half-maximal inhibitory concentration: 16 nM
Beside the measured number, compound 4's estimate is 5.0-fold (0.70 log units) above it, outside the stated range (below it).
By their numbers in this assay, from the lowest: compound 4; then compounds 3, 1 and 2 (each within the scatter of the next).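

In this assay, this position on the shared core responds to exchanging the whole substituent, although changing only the group carried on the 1,2-oxazol-5-yl ring stayed within the scatter, as in a 1.1-fold higher number from compound 1 to compound 2 (0.04 log units; within the scatter). Bringing in 1-methyl-1H-pyrazol-3-yl gives a 4.9-fold lower number from compound 3 to compound 4 (0.69 log units; beyond the scatter), a 5.3-fold lower number from compound 1 to compound 4 (0.72 log units; beyond the scatter) and a 5.8-fold lower number from compound 2 to compound 4 (0.76 log units; beyond the scatter), so all three steps run in the same direction and lie beyond the scatter, whichever of the three leaving groups is replaced. Nothing available accounts for this gain.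

From the compounds shown here alone, it remains open whether the lower number goes with the new ring or with the absence of the groups carried on the 1,2-oxazol-5-yl ring, a question that an unsubstituted 1,2-oxazol-5-yl group would help to separate. Going by these compounds, how far the methyl matters is also open, and 1H-pyrazol-3-yl and 1-ethyl-1H-pyrazol-3-yl groups would test it.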